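Replacing the nitrophenyl arm of a thiophene piperazine

The source may hold more compounds than are shown below. What is called first, only, known or untested is meant among the compounds shown, and "the series" means these compounds.

Three compounds share one core, differing only in the aryl group on the piperazine nitrogen. Compound 1 `Nc1scc(CN2CCN(c3ccc(F)cc3Cl)CC2)c1C(=O)c1ccc(Cl)cc1` gives 6.1% in a functional assay on CHO cells with adenosine receptor A1 (Homo sapiens) as the target, read by cAMP accumulation and immunoassay, with a stated time of 6 min, tested at 0.01 uM (on this read-out lower numbers stand for a stronger effect and higher numbers for a weaker effect at the one concentration tested), compound 2 `Nc1scc(CN2CCN(c3ccc([N+](=O)[O-])cc3)CC2)c1C(=O)c1ccc(Cl)cc1` gives -12%, and compound 3 `Nc1scc(CN2CCN(c3cccnc3)CC2)c1C(=O)c1ccc(Cl)cc1` gives 3.2%. Compound 2 stands lowest of the three, with steps to the others both beyond the scatter: a number 15.2 percentage points higher from compound 2 to compound 3 (beyond the scatter) and a number 18.1 percentage points lower from compound 1 to compound 2 (beyond the scatter). Compound 4 `Nc1scc(CN2CCN(c3cccc(F)c3F)CC2)c1C(=O)c1ccc(Cl)cc1` differs from compound 2 in this way: 2,3-difluorophenyl in place of 4-nitrophenyl on an amine nitrogen in a ring. Both steps away from the nitrophenyl group went upward by a modest amount, so a similar upward step from compound 2 is expected here: a number 16 percentage points higher from compound 2 to compound 4 (beyond the scatter). Compound 4 is therefore estimated at 4%, within a range from -10% to 18%.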

Compound 4, a percentage reported as activity, at one concentration (the size of the read-out at that concentration, not a potency): -13%
Compound 4: the middle estimate sits 17 percentage points above what was measured, and the stated range ends above it.
By their numbers in this assay, from the lowest: compounds 4 and 2 (each within the scatter of the next); then compounds 3 and 1 (each within the scatter of the next).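

Swapping 4-nitrophenyl for 2,3-difluorophenyl on the piperazine amine nitrogen left the number in this assay essentially unchanged (a number 1 percentage points lower from compound 2 to compound 4 (within the scatter)), so the low number does not depend on the nitro group. The 2,3-difluorophenyl group also stands apart from the other two aryl groups (a number 16.2 percentage points lower from compound 3 to compound 4 (beyond the scatter); a number 19.1 percentage points lower from compound 1 to compound 4 (beyond the scatter)), although compound 1 also carries halogens. Nothing available explains these differences.

Going by these compounds, whether a phenyl ring bearing a single fluorine, an amine or a carboxylic acid would give a similarly low number remains open. So does whether these differences hold at other concentrations.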